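The source may report more compounds than this note shows. Statements on the series, on what has been measured and on what is new or still open speak of the compounds shown alone.

Measured compounds:
compound 1, `COc1ccc(OC)c(/C=C/C(=O)Nc2cc3c(Nc4ccc(F)c(Cl)c4)ncnc3cc2OC)c1` — in a functional assay on HeLa cells (Homo sapiens) for cytotoxicity, read by MTT assay, with a stated time of 72 h (a lower number here means a stronger inhibitor, a higher number a weaker inhibitor), compound 1 gives "not determined" (no result reported)
compound 2, `COc1cc2ncnc(Nc3ccc(F)c(Cl)c3)c2cc1NC(=O)/C=C/c1ccccc1[N+](=O)[O-]` — in this assay compound 2 gives "not determined" (no result reported)
compound 3, `COc1ccc(OC)c(/C=C/C(=O)Nc2cc3c(Nc4ccc(F)c(Cl)c4)ncnc3cc2O[C@H]2CCOC2)c1` — in this assay compound 3 gives 26800 nM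

Compound 3 is the only one of the three with a number in this assay, so it cannot be ranked against compound 1 or compound 2; for those two, the outcome is simply unknown. Compound 3 itself sits at a weak level of inhibition in this assay, a concentration far up in the micromolar region.

Compound 4, `O=C(/C=C/c1ccc(Br)cc1)Nc1cc2c(Nc3ccc(F)c(Cl)c3)ncnc2cc1O[C@H]1CCOC1`, has not yet been measured. Its structure differs from compound 3 in a single place: 4-bromophenyl in place of 2,5-dimethoxyphenyl on a double-bonded chain carbon bound to a double-bonded chain carbon. The rest of the molecule, including the shared core and the double-bonded chain that carries the changed ring, is kept as it is.

Among the compounds with values here, no pair of measured compounds in this set differs in only one place, so there is no measured step to lean on. The change swaps one aromatic ring for another of similar size, and with nothing in the data pointing either way, the expectation is a step from compound 3 to compound 4 of a 1.2-fold lower number from compound 3 to compound 4 (0.09 log units; within the scatter), that is, no change beyond the usual scatter of this assay.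

Compound 4 is therefore expected to give about 22000 nM in this assay, with a plausible range from 7000 nM to 65000 nM.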

Compound 4, half-maximal inhibitory concentration: 27500 nM
For compound 4 the middle estimate is 1.3-fold (0.10 log units) below the measured one; the measured number falls inside the stated range.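

Placing 4-bromophenyl in place of 2,5-dimethoxyphenyl on a double-bonded chain carbon bound to a double-bonded chain carbon gives a 1.0-fold higher number from compound 3 to compound 4 (0.01 log units; within the scatter) in this assay. Within the data shown here, this is the first measured step at this position, and it shows that the methoxy groups can go and a bromine can come in without the number moving beyond the scatter, so for this pair the choice between these two rings does not separate the compounds. No measurement is available that could account for this flat result.

As far as these compounds go, it remains open whether this position would respond to a different kind of group, such as an amine or a carboxylic acid on the phenyl ring, or to a longer chain in place of the ethenyl link. From the compounds shown here alone, compound 1 and compound 2 have no number in this assay, so any steps involving them cannot be read, and the effect of the group on the shared core that sets compound 1 apart from compound 3 remains unknown.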